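The source may report more compounds than this note shows. Statements on the series, on what has been measured and on what is new or still open speak of the compounds shown alone.

Compound 1 `O=C(CBr)Nc1ccc(C(=O)/C=C/c2ccc(Cl)cc2)cc1`: 44%
Compound 2 `COc1ccc(/C=C/C(=O)c2ccc(NC(=O)CBr)cc2)cc1`: 37%
Compound 3 `O=C(CBr)Nc1ccc(C(=O)/C=C/c2ccco2)cc1`: 30%

These three compounds share one core and differ only at the far end of the double-bonded chain. In a functional assay on the whole organism (strain albino) for inhibition, with Rattus norvegicus as the target, read by paw edema, with stated times of 30 min and 1 h, at a dose of 100 mg/kg by the oral route (on this read-out lower numbers stand for less inhibition and higher numbers for more inhibition at the one dose given (going by the name of the read-out)), compound 3 gives the lowest of the three numbers. Its nearest neighbour is compound 2, and the gap between them, a number 7 percentage points lower from compound 1 to compound 2 (within the scatter) aside, is within the usual scatter, so nothing can be said about an order between those two. Among the compounds with values here, the only step that reaches beyond the scatter is a number 14 percentage points lower from compound 1 to compound 3 (beyond the scatter), a modest one.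

Compound 4 `CC(Br)C(=O)Nc1ccc(C(=O)/C=C/c2ccco2)cc1` has not been measured. It differs from compound 3 by methyl in place of hydrogen on a saturated chain carbon bound to a bromine atom and a carbonyl carbon. Neither measured step speaks to this change: both alter the group at the end of the double-bonded chain, while the bromine-bearing chain carbon stays untouched in all three compounds. Within the data shown here, with no comparable step to draw on, the expectation is a step of no size beyond the scatter, no change at the digits printed from compound 3 to compound 4 (within the scatter). The estimate for compound 4 in this assay is therefore 30%, expected to lie between 18% and 42%.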

Compound 4, a percentage reported as inhibition, in the whole organism at one dose (the size of the read-out at that dose, not a potency): 30%
Compound 4: the middle estimate sits on the measured number at the digits printed; low and high end bracket the measured number.
By their numbers in this assay, from the lowest: compounds 3, 4, 2 and 1 (each within the scatter of the next, the first and the last beyond it).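

In this assay, within the data shown here, the saturated chain carbon bound to a bromine atom and a carbonyl carbon is changed for the first time, and methyl in place of hydrogen there gives no change at the digits printed from compound 3 to compound 4 (within the scatter). The earlier steps shown here only described changes at the far end of the double-bonded chain, whereas this one shows that, with furan-2-yl at that end, the added methyl produces no shift that can be told apart from the scatter. Nothing available explains why the number holds at this carbon.

As far as these compounds go, whether methyl has the same lack of effect with the 4-chlorophenyl group of compound 1 at the far end remains open. Also open, from the compounds shown here alone, is what a larger group such as ethyl or phenyl, or an amine in place of the bromine, would do at this carbon.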